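The source may report more compounds than this note shows. Statements on the series, on what has been measured and on what is new or still open speak of the compounds shown alone.

Measured in a functional assay on HeLa cells (Homo sapiens) for antiproliferative activity, read by CCK-8 assay, with a stated time of 72 h; on this read-out higher numbers stand for weaker inhibition and lower numbers for stronger inhibition:
Compound 1, `Cc1ccccc1C(=O)Nc1cccc(-c2oc3cc(-c4ccc(F)cc4)ccc3c(=O)c2O)c1`: 11900 nM.
Compound 2, `O=C(Nc1cccc(-c2oc3cc(-c4ccc(F)cc4)ccc3c(=O)c2O)c1)c1ccc(C(F)(F)F)cc1`: 17400 nM.
Compound 3, `COc1cccc(C(=O)Nc2cccc(-c3oc4cc(-c5ccc(F)cc5)ccc4c(=O)c3O)c2)c1`: 5650 nM.

Compound 2 carries the highest number of the three; its step to compound 1, a 1.5-fold higher number from compound 1 to compound 2 (0.17 log units; within the scatter), lies within the scatter, whereas a 3.1-fold lower number from compound 2 to compound 3 (0.49 log units; beyond the scatter) lies beyond it. Compound 4, `COc1ccc(C(=O)Nc2cccc(-c3oc4cc(-c5ccc(F)cc5)ccc4c(=O)c3O)c2)c(F)c1`, is not yet measured; the change is 2-fluoro-4-methoxyphenyl in place of 4-(trifluoromethyl)phenyl on a carbonyl carbon. Among the measured compounds shown here, the measured step that bears on this is a 3.1-fold lower number from compound 2 to compound 3 (0.49 log units; beyond the scatter), where a methoxyphenyl also took the place of the trifluoromethylphenyl group, and a 2.1-fold lower number from compound 1 to compound 3 (0.32 log units; beyond the scatter) points the same way, so a modest lowering of the number in this assay is expected for compound 4, though the added fluorine and the different methoxy position have no measured precedent here. For compound 4 the estimate is 7000 nM, expected to fall between 3000 nM and 17000 nM. The expected step is a 2.5-fold lower number from compound 2 to compound 4 (0.40 log units; beyond the scatter).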

Compound 4, half-maximal inhibitory concentration: 16100 nM
Compound 4: middle estimate off by 2.3-fold (0.36 log units), on the low side; the measured number falls inside the stated range.
By their numbers in this assay, from the lowest: compound 3; then compounds 1, 4 and 2 (each within the scatter of the next).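

In this assay, a methoxyphenyl group on the carbonyl carbon does not by itself lower the number: 2-fluoro-4-methoxyphenyl in place of 4-(trifluoromethyl)phenyl gives a step within the scatter (a 1.1-fold lower number from compound 2 to compound 4 (0.03 log units; within the scatter)), as does 2-fluoro-4-methoxyphenyl in place of 2-methylphenyl (a 1.4-fold higher number from compound 1 to compound 4 (0.13 log units; within the scatter)). Among these four compounds, 3-methoxyphenyl alone stands apart (a 2.8-fold higher number from compound 3 to compound 4 (0.45 log units; beyond the scatter)). No measurement here accounts for that difference.

Compound 3 and compound 4 differ in both the fluorine and the methoxy placement, so neither feature can be singled out. As far as these compounds go, the effect of 4-methoxyphenyl without fluorine, or of an aminophenyl or carboxyphenyl group on this carbonyl carbon, remains open.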